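Moving the bromine on the benzylic ring of compound 3

The compounds below may be only part of what the source reports. "The series", "measured", "known", "first", "only" and "open" are said of these compounds alone.

Of the compounds shown here, three sharing one core have been measured in an assay on HEK293 cells for displacement of a labelled ligand from prostaglandin D2 receptor 2 (Homo sapiens); on this read-out lower numbers stand for stronger inhibition and higher numbers for weaker inhibition. Compound 1 `CCCCCCSc1nc2ccccc2n1CC(=O)O` gives 1360 nM, compound 2 `CCOC(=O)CCCSc1nc2ccccc2n1CC(=O)O` gives 4410 nM, and compound 3 `O=C(O)Cn1c(SCc2ccc(Br)cc2)nc2ccccc21` gives 220 nM. Compound 3 stands lowest of the three: compound 1 is its nearest neighbour, with a 6.2-fold lower number from compound 1 to compound 3 (0.79 log units; beyond the scatter), and compound 2 its furthest, with a 20-fold lower number from compound 2 to compound 3 (1.30 log units; beyond the scatter). The step of a 3.2-fold higher number from compound 1 to compound 2 (0.51 log units; beyond the scatter) runs the other way.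

Compound 4 `O=C(O)Cn1c(SCc2cccc(Br)c2)nc2ccccc21` differs from compound 3 in one place: 3-bromophenyl in place of 4-bromophenyl on a saturated chain carbon bound to a sulfur. For the measured compounds named here, none of the measured steps changes where the bromine sits on the ring; the steps from compound 1 and compound 2 to compound 3 only exchange a chain for the 4-bromophenyl group. So there is nothing in the measured set that directly bears on this change, and the expectation for compound 4 in this assay rests on compound 3 alone, allowing for a step in either direction. Compound 4 is estimated at 300 nM, with a range from 90 nM to 1000 nM, which would be a step of a 1.4-fold higher number from compound 3 to compound 4 (0.13 log units; within the scatter), expected to stay within or just beyond the scatter.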

Compound 4, half-maximal inhibitory concentration: 370 nM
Beside the measured number, compound 4's estimate is 1.2-fold (0.09 log units) below it; the range from low to high includes it.
By their numbers in this assay, from the lowest: compounds 3 and 4 (each within the scatter of the next); then compound 1; then compound 2.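

In this assay, for the compounds shown here, moving the bromine gives a step (a 1.7-fold higher number from compound 3 to compound 4 (0.23 log units; within the scatter)), so 3-bromophenyl and 4-bromophenyl on a saturated chain carbon bound to a sulfur cannot be told apart here, something the earlier steps could not show, as each of them exchanged a whole chain. The advantage of the aryl group over the chains also holds with the new group (a 3.7-fold lower number from compound 1 to compound 4 (0.57 log units; beyond the scatter); a 12-fold lower number from compound 2 to compound 4 (1.08 log units; beyond the scatter)), so it is not tied to the 4-bromophenyl group alone. Nothing available explains why the two bromophenyl groups read alike.

On these data alone, what an unsubstituted phenyl on that carbon, or chlorine or methoxy in place of the bromine, would give remains open. So does whether an amide in place of the carboxylic acid would keep these numbers.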